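Replacing 1-acetamidocyclopropyl by 1-acetamidopropyl: compound 4

The source may hold more compounds than are shown below. What is called first, only, known or untested is meant among the compounds shown, and "the series" means these compounds.

Compound 1 `CCOC(=O)/C=C/C(=O)N(CC(N)=O)NC(=O)[C@@H]1CCCN1C(=O)[C@H]1CCCCN1C(C)=O` gives 638 nM in an assay on isolated protein for inhibition of legumain (Mus musculus), read by fluorescence, with stated times of 30 s and 2.5 h; on this read-out lower numbers stand for stronger inhibition and higher numbers for weaker inhibition.
Compound 2 `CCOC(=O)/C=C/C(=O)N(CC(N)=O)NC(=O)[C@@H]1CCCN1C(=O)C1(NC(C)=O)CC1` gives 9.3 nM in this assay.
Compound 3 `CCOC(=O)C1OC1C(=O)N(CC(N)=O)NC(=O)[C@@H]1CCCN1C(=O)C1(NC(C)=O)CC1` gives 4.4 nM in this assay.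

Compound 3 holds the lowest number of the three in this assay. Its nearest neighbour is compound 2, separated from it by the step of a 2.1-fold lower number from compound 2 to compound 3 (0.33 log units; beyond the scatter), a modest one. Compound 1 lies furthest away, its number far above those of compounds 2 and 3.

Compound 4 `CCOC(=O)C1OC1C(=O)N(CC(N)=O)NC(=O)[C@@H]1CCCN1C(=O)[C@H](CC)NC(C)=O` carries the change (1-acetamidopropyl in place of 1-acetamidocyclopropyl on a carbonyl carbon). Among the compounds with values here, only one measured step touches that carbonyl carbon: a 69-fold lower number from compound 1 to compound 2 (1.84 log units; beyond the scatter), a large one, which brought in 1-acetamidocyclopropyl in place of a six-membered ring group. Within the data shown here, no measured step exchanges 1-acetamidocyclopropyl for an open chain of the same size, so the direction of the new step rests on thin ground. A small step toward a higher number in this assay, possibly within the scatter, is expected. Compound 4 is therefore estimated at 9 nM, within a range from 3 nM to 30 nM. This estimate amounts to the expected step of a 2.0-fold higher number from compound 3 to compound 4 (0.31 log units; beyond the scatter).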

Compound 4, half-maximal inhibitory concentration: 8.1 nM
For compound 4 the middle estimate is 1.1-fold (0.05 log units) above the measured one, and the stated range covers the measured number.
By their numbers in this assay, from the lowest: compounds 3, 4 and 2 (each within the scatter of the next, the first and the last beyond it); then compound 1.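

In this assay, the exchange of 1-acetamidocyclopropyl for 1-acetamidopropyl on this carbonyl carbon amounts to a 1.8-fold higher number from compound 3 to compound 4 (0.27 log units; within the scatter), a step that does not separate the two compounds. Within the data shown here, the only earlier step at this carbonyl carbon, a 69-fold lower number from compound 1 to compound 2 (1.84 log units; beyond the scatter), had replaced a six-membered ring group and could not show whether the three-membered carbon ring itself was needed; in this one pair, the open chain with the same heavy-atom count reads the same as that ring within the scatter. Nothing measured here bears on the reason for this result.

Going by these compounds, it remains open whether the opposite configuration at the defined stereocentre of 1-acetamidopropyl, or a longer chain such as 1-acetamidobutyl, would keep the number in the same place. On these data alone, it is also open whether the same exchange would read alike on the core of compound 2.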